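Trimming the End Group of Compound 2 to Acetyl

The source may hold more compounds than are shown below. What is called first, only, known or untested is meant among the compounds shown, and "the series" means these compounds.

In a functional assay on HCT-116 cells (Homo sapiens) for inhibition, read by colorimetric assay, with a stated time of 3 days (on this read-out lower numbers stand for stronger inhibition and higher numbers for weaker inhibition), compound 1 (`O=C(CCCCCCNC(=O)C(O)(O)C(F)(F)F)Nc1ccncc1`) gives 6670 nM and compound 3 (`O=C(CCCCCCNC(=O)C(O)(O)C(F)(F)F)Nc1nc2ccc(Br)cc2o1`) gives 12100 nM. Compound 2 (`O=C(CCCCCCNC(=O)c1cc(=O)c(O)co1)Nc1ccccc1`) returns no number, only a limit of the assay, > 100000 nM. Going by the values given here, it is the one compound at the limit of > 100000 nM in this assay, at which 1 of the 3 values shown sits.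

Compound 4 (`CC(=O)C(=O)NCCCCCCC(=O)Nc1ccccc1`) differs from compound 2 at one end of the molecule: a group of 3 heavy atoms (2 carbon, 1 oxygen; no ring) in place of a group of 8 heavy atoms (5 carbon, 3 oxygen; one six-membered aromatic ring with 1 hetero atom), on a carbonyl carbon. Acetyl thus takes the place of the larger ring-bearing group on the same carbonyl carbon. No measured step among these compounds covers such a change, so the expectation rests on compound 2, whose reading is a limit at > 100000 nM. In this assay, only a modest shift toward stronger inhibition is expected, an at least 1.6-fold lower number from compound 2 to compound 4 (0.22 log units; that floor lies within the scatter), and another reading at the limit would be no surprise. The estimate for compound 4 is 60000 nM, with an expected range from 15000 nM to 200000 nM.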

Compound 4, half-maximal inhibitory concentration: > 100000 nM
Compound 4 was reported as a limit; the forecaster's own chance of this, stated with the estimate: 50%; at least 1.6-fold (0.22 log units) between middle value and limit.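

Compound 2 and compound 4 both return only a limit in this assay, and no step can be read between them. The compounds shown leave open whether acetyl or the larger ring-bearing group on the same carbonyl carbon gives stronger inhibition.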